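Opening the Step from Compound 2 to Compound 4

This account rests on a few compounds, and the source may have more. Where it says the series, first, only, none or still open, it means among the compounds named here.

Measured so far:
- compound 1 `O=C(CN(c1nc(Cl)nc2[nH]cnc12)C1CC1)NCC(=O)OCc1ccccc1`: 21.7%
- compound 2 `C[C@@H](O)[C@H](NC(=O)CN(c1ncnc2c1ncn2C1CCCCO1)C1CC1)C(=O)OCc1ccccc1`: 10.9%
- compound 3 `CSCC[C@H](NC(=O)CN(c1nc(Cl)nc2[nH]cnc12)C1CC1)C(=O)OCc1ccccc1`: 31.6%

Three compounds have been run in a functional assay on the whole organism (Tail, strain ICR) with Mus musculus as the target, in the tail flick test, with a stated time of 120 min, at a dose of 25 umol/kg by the oral route; on this read-out lower numbers stand for a weaker effect and higher numbers for a stronger effect at the one dose given. Compound 2 stands lowest of the three: in this assay compound 2 gives 10.9%, while compound 1 gives 21.7% and compound 3 gives 31.6%, both of them higher by more than the usual scatter.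

The next compound, compound 4 `CSCC[C@H](NC(=O)CN(c1ncnc2c1ncn2C1CCCCO1)C1CC1)C(=O)OCc1ccccc1`, has not yet been measured. It differs from compound 2 in one place: 2-(methylsulfanyl)ethyl in place of 1-hydroxyethyl on a saturated chain carbon bound to an amide-type nitrogen and a carbonyl carbon.

Within the data shown here, only one measured step bears on this change, and only in part. Between compound 1 and compound 3, which share the core of compound 1 rather than the core of compound 2, the same 2-(methylsulfanyl)ethyl group replaced hydrogen at the same position, and the result was a number 9.9 percentage points higher from compound 1 to compound 3 (within the scatter). Among the measured compounds shown here, no measured pair shows what the loss of the 1-hydroxyethyl group does on its own, so that half of the change is unsupported.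

Compound 4 is therefore expected to gain somewhat over compound 2 in this assay, with a step of about a number 8.1 percentage points higher from compound 2 to compound 4 (within the scatter), of a size that may or may not exceed the scatter. The estimate for compound 4 is 19%, in a range from 6% to 33%.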

Compound 4, a percentage reported as activity, at one dose (the size of the read-out at that dose, not a potency): 28.7%
Beside the measured number, compound 4's estimate is 9.7 percentage points below it; low and high end bracket the measured number.
By their numbers in this assay, from the lowest: compound 2; then compounds 1, 4 and 3 (each within the scatter of the next).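

In this assay, the change on a saturated chain carbon bound to an amide-type nitrogen and a carbonyl carbon, 2-(methylsulfanyl)ethyl in place of 1-hydroxyethyl, gives a number 17.8 percentage points higher from compound 2 to compound 4 (beyond the scatter) on the core of compound 2. The earlier step with the same entering group, a number 9.9 percentage points higher from compound 1 to compound 3 (within the scatter) on the core of compound 1, started from hydrogen and stayed within the scatter, so this is the first step at the position shown to clear it. Nothing measured here accounts for the step, which stands as an observation on a single pair of compounds.

The compounds shown leave open whether the step reflects the departure of 1-hydroxyethyl, which carries a hydrogen-bond donor, or the arrival of 2-(methylsulfanyl)ethyl, which carries none; the core of compound 2 appears here with neither hydrogen nor any other simple group at this carbon. A plain butyl chain or a hydroxymethyl group on the same carbon would bear on that question, the first without sulfur and the second with a shorter chain that keeps the hydroxyl.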